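The source may report more compounds than this note shows. Statements on the series, on what has been measured and on what is new or still open speak of the compounds shown alone.

Working notes on the series, values in a functional assay on DU-145 cells (Homo sapiens) for inhibition, read by trypan blue exclusion, with a stated time of 96 h; a lower number here means a stronger inhibitor of growth, a higher number a weaker inhibitor of growth:
- Compound 1 `Cc1ccc(CS/C(=C/c2ccccc2F)C(=O)c2ccc(Cl)cc2)cc1`: 10000 nM
- Compound 2 `CN(C)c1ccc(/C=C(/SCc2ccccc2Cl)C(=O)c2ccc(Cl)cc2)cc1`: > 100000 nM (a limit of the assay)
- Compound 3 `Cc1ccc(CS/C(=C/c2cc(Cl)cc(Cl)c2)C(=O)c2ccc(Cl)cc2)cc1`: 10000 nM

Compound 3 stands level with compound 1 on these numbers. Putting 3,5-dichlorophenyl in place of 2-fluorophenyl gave no change at the digits printed from compound 1 to compound 3 (within the scatter).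

Next is compound 4 `Cc1ccc(CS/C(=C/c2ccc(N(C)C)cc2)C(=O)c2ccc(Cl)cc2)cc1`, with 4-(dimethylamino)phenyl in place of 3,5-dichlorophenyl on a double-bonded chain carbon bound to a double-bonded chain carbon.

Among the measured compounds shown here, the one measured step at this place did not involve 4-(dimethylamino)phenyl, so it offers only weak guidance. Compound 2 carries that group at the same place but also differs from compound 4 elsewhere. Compound 2 gives > 100000 nM, which is a limit of the assay. That single result leans the expectation towards weaker growth inhibition.

In this assay a step in that direction, beyond the scatter, is expected: a 3.0-fold higher number from compound 3 to compound 4 (0.48 log units; beyond the scatter). The estimated value for compound 4 is 30000 nM, with an expected range of 8000 nM to 100000 nM.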

Compound 4, concentration for 50% growth inhibition: > 100000 nM
Compound 4: a limit, no number; the forecaster's own chance of this, stated with the estimate: 35%; at least 3.3-fold (0.52 log units) between middle value and limit.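

On a double-bonded chain carbon bound to a double-bonded chain carbon, the group carried does matter in this assay, although the earlier change of aryl group showed no shift: 4-(dimethylamino)phenyl gives an at least 10-fold higher number from compound 3 to compound 4 (1.00 log units; beyond the scatter) and an at least 10-fold higher number from compound 1 to compound 4 (1.00 log units; beyond the scatter). Compound 4 reads > 100000 nM, which is a limit of the assay, so both steps give only the smallest size the data allow. The step between compound 2 and compound 4, which both carry 4-(dimethylamino)phenyl at this place, cannot be read, because both values are limits: the limit of > 100000 nM in this assay, at which 2 of the 4 values shown sit.

Going by these compounds, it remains open whether the weaker growth inhibition belongs to the dimethylamino group specifically or extends to other groups at this place. A 4-methoxyphenyl or 4-aminophenyl group there would help to separate these readings.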